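A few compounds are considered here, and "the series" means these few. Any claim that something is new, unique, unknown or untested is made for them only; others in the source may bear on it.

In an ADME assay on MT4 cells (Homo sapiens) for cytotoxicity (a lower number here means that less compound is tolerated, a higher number that more compound is tolerated), compound 1 `FC(F)(F)c1cccc(NC(=S)Nc2ccc(I)cc2)c1` gives 10000 nM and compound 2 `Cc1ccc(NC(=S)Nc2cccc(C(F)(F)F)c2)cc1Cl` gives 20000 nM. Compound 3 `CCNC(=S)Nc1cccc(C(F)(F)F)c1` reads > 100000 nM, which is a limit of the assay and not a number. Among the measured compounds shown here, it is the only compound of the three at that limit, so how far its true value lies beyond it is not known.

Compound 4 `C=C(C)CNC(=S)Nc1cccc(C(F)(F)F)c1` carries 1-methylethenyl in place of methyl on a saturated chain carbon bound to an amide-type nitrogen. For the measured compounds named here, the one measured step that bears on this change is an at least 10-fold higher number from compound 1 to compound 3 (1.00 log units; beyond the scatter), which lies beyond the scatter and replaced 4-iodophenyl with ethyl. Compound 4 keeps a chain with no ring on that nitrogen, so it is expected to stay much closer to compound 3 than to compound 1. The expected change is small, and if there is one it can be read only as a lower number: an at least 1.4-fold lower number from compound 3 to compound 4 (0.15 log units; that floor lies within the scatter). For compound 4 the estimated value is 70000 nM, with an expected range from 30000 nM to 100000 nM.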

Compound 4, half-maximal cytotoxic concentration: 43000 nM
Compound 4: middle estimate off by 1.6-fold (0.21 log units), on the high side, within the range that was stated.
By their numbers in this assay, from the lowest: compounds 1 and 2 (each within the scatter of the next); then compound 4. At a limit, above all of these: compound 3.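

In this assay, among the compounds shown here, the earlier compounds showed only that a chain in place of 4-iodophenyl raises the number; this result shows that the chain itself matters, with an at least 2.3-fold lower number from compound 3 to compound 4 (0.36 log units; beyond the scatter) once 1-methylethenyl replaces methyl, although no ring enters. The gain over the aryl compound is still largely kept, with a 4.3-fold higher number from compound 1 to compound 4 (0.63 log units; beyond the scatter) for a chain that carries no ring on that nitrogen. Compound 3 stands at a limit of the assay and not at a number, so the first of these steps is only a floor: the limit of > 100000 nM in this assay, at which 1 of the 4 values shown sits.

The compounds shown leave open whether the lower number goes with the added carbons or with the double bond, which the saturated 2-methylpropyl chain on the same nitrogen could separate. They also leave open how a hydroxyl group or an amine at the end of the chain would read.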